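Dropping One Fluorine: What Compound 4 May Tolerate

A few compounds are considered here, and "the series" means these few. Any claim that something is new, unique, unknown or untested is made for them only; others in the source may bear on it.

The measured compounds:
Compound 1, `O=C(Nc1cc(F)c(F)c(F)c1)N1Cc2c(-c3ccc(F)cc3F)cnn2CC1C1CC1`, gives 32100 nM.
Compound 2, `C[C@H]1Cn2ncc(N3CC(c4ccccc4)CC3=O)c2CN1CC(=O)Nc1cc(F)c(F)c(F)c1`, reaches only a limit of the assay, > 2000 nM.
Compound 3, `CC1(C)CN(C(=O)Nc2cc(F)c(F)c(F)c2)Cc2c(N3CC(C#N)CC3=O)cnn21`, likewise reaches only a limit, > 200000 nM.

These values come from a toxicity assay on HepG2 2.2.15 cells (Homo sapiens) for cytotoxicity, read by CellTiter-Glo; a higher number here means that more compound is tolerated, a lower number that less compound is tolerated. Among the three, compound 1 is the only one with an actual number; the other two stop at a limit, so they cannot be set against it as a measured step. The limits themselves sit at the limit of > 2000 nM in this assay, at which 1 of the 3 values shown sits, and (the limit of > 200000 nM in this assay, at which 1 of the 3 values shown sits).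

Compound 4, `O=C(Nc1cc(F)c(F)c(F)c1)N1Cc2c(-c3ccc(F)cc3)cnn2CC1C1CC1`, has not been measured. It is compound 1 with a single change: hydrogen in place of fluoro on an aromatic carbon. Going by the values given here, no step between two measured compounds in this assay is known, so nothing here shows what loss of a fluoro from this ring does to how much compound cells tolerate.

With so small a change, the expectation is a step of no size beyond the usual scatter, in either direction: from compound 1 to compound 4 the expected change is a 1.1-fold lower number from compound 1 to compound 4 (0.03 log units; within the scatter). Compound 4 is therefore estimated at 30000 nM, with a likely range from 12000 nM to 80000 nM.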

Compound 4, half-maximal cytotoxic concentration: 38500 nM
Estimate against measurement, compound 4: 1.3-fold (0.11 log units) below; measured number inside the range.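

Going from 2,4-difluorophenyl to 4-fluorophenyl gives a 1.2-fold higher number from compound 1 to compound 4 (0.08 log units; within the scatter) in this assay, and this is the first measured step among the compounds shown. It shows that on this aromatic carbon, ortho to a large group, fluoro and hydrogen cannot be told apart by how much compound the cells tolerate, so this fluoro is not needed to keep the tolerated level of compound 1. The two assay limits in the data do not bear on this pair, so nothing shown explains the result.

Going by these compounds alone, compound 2 and compound 3 stop at limits, so no steps to them can be read, and this single pair speaks only for the swap of fluoro and hydrogen at this one position. Going by these compounds, whether a larger or very different group on the same carbon, such as a methoxy group, an amine or a carboxylic acid, would leave the tolerated level as it stands remains open, as does the effect of taking away the remaining fluoro on this ring.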